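Volume of distribution across amide variations of a shared core

The compounds below may be only part of what the source reports. "The series", "measured", "known", "first", "only" and "open" are said of these compounds alone.

Measured so far:
compound 1, `CCn1c(-c2cnc(C)nc2)nc2c(O[C@H]3CCN(C(=O)C4CC4)C3)ncnc21`: 2.8 L/kg
compound 2, `CCn1c(-c2ccc(C(F)(F)F)nc2)nc2c(O[C@H]3CCN(C(=O)N4CC(OC)C4)C3)ncnc21`: 4.2 L/kg

Among the compounds with values here, in an ADME assay (Rattus norvegicus, strain Wistar Han) for pharmacokinetics (a higher number here means that more of the compound sits outside the plasma, a lower number that more of the compound stays in the plasma), compound 1 gives 2.8 L/kg, the lower of the two numbers so far. Compound 2 gives 4.2 L/kg, and the gap to compound 1 lies within the scatter, so the two cannot be put in order. Within the data shown here, compound 2 differs from compound 1 in more than one place, and no single-change step between measured compounds exists, so there is no measured precedent for the change that leads to compound 3.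

Compound 3 is `CCn1c(-c2cnc(C)nc2)nc2c(O[C@H]3CCN(C(=O)[C@H]4C[C@@H](OC)C4)C3)ncnc21`. Its difference from compound 1 is:
3-methoxycyclobutyl in place of cyclopropyl on a carbonyl carbon

Among the measured compounds shown here, the data give no step that isolates this change. For the measured compounds named here, with only two measured compounds, both close to each other in this assay, the expectation is that the step from compound 1 to compound 3 stays within the scatter, if anything leaning slightly upward; the expected step is a 1.1-fold higher number from compound 1 to compound 3 (0.06 log units; within the scatter). Compound 3 is accordingly estimated at 3.2 L/kg, with a range from 1.8 L/kg to 5.6 L/kg, and a measurement anywhere in that range would be consistent with both measured compounds.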

Compound 3, volume of distribution: 2.5 L/kg
Compound 3: the middle estimate sits 1.3-fold (0.11 log units) above what was measured; low and high end bracket the measured number.
By their numbers in this assay, from the lowest: compounds 3, 1 and 2 (each within the scatter of the next).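

Within the data shown here, replacing cyclopropyl with 3-methoxycyclobutyl on a carbonyl carbon gives the first single-change step, a 1.1-fold lower number from compound 1 to compound 3 (0.05 log units; within the scatter), in this assay. At this position, whose carbonyl carbon also carries an amide-type nitrogen in a ring, the group grows from 3 heavy atoms to 6 and gains 1 oxygen, 1 hydrogen-bond acceptor and 2 defined stereocentres, yet the step stays within the scatter. Nothing shown explains why the read-out does not separate the two groups.

From the compounds shown here alone, it remains open whether an amine, a carboxylic acid or a longer chain on the same carbonyl carbon would give a step beyond the scatter, and whether the other stereochemical arrangements of the 3-methoxycyclobutyl group would read like compound 3. Going by these compounds, it is also open whether the same replacement would give a similar step on the core of compound 2, which differs from compound 1 in more than one place and so offers no comparison for this change.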